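Benzoate ester variation: trifluoromethyl replaced by methyl

The compounds below may be only part of what the source reports. "The series", "measured", "known", "first", "only" and "open" are said of these compounds alone.

The three measured compounds share the core of compound 1 `COc1cccc(C(=O)Oc2cc3c(cc2C)[C@@H](C(C)C)CC=C3C)c1` and differ only in the substituent on the benzoate ring. In a functional assay on U-251 cells (Homo sapiens) for antiproliferative activity, read by sulforhodamine B assay, with a stated time of 48 h, tested at 50 uM (a lower number here means less inhibition, a higher number more inhibition at the concentration tested (going by the name of the read-out)), compound 1 is reported as "not active" (no number reported), without a number. Compound 2 `CC1=CC[C@H](C(C)C)c2cc(C)c(OC(=O)c3cccc(Cl)c3)cc21` gives 0.9% in this assay, and compound 3 `CC1=CC[C@H](C(C)C)c2cc(C)c(OC(=O)c3cccc(C(F)(F)F)c3)cc21` gives 29.3%. Compound 3 therefore stands highest of the two numbers, separated from compound 2 by a number 28.4 percentage points higher from compound 2 to compound 3 (beyond the scatter), with compound 1 as the entry without a number. Compound 4 `CC1=CC[C@H](C(C)C)c2cc(C)c(OC(=O)c3cccc(C)c3)cc21` differs from compound 3 by methyl in place of trifluoromethyl on an aromatic carbon. Within the data shown here, the only measured step that bears on this change is a number 28.4 percentage points higher from compound 2 to compound 3 (beyond the scatter), which shows that the trifluoromethyl is the one substituent so far that carries the read-out clearly above the scatter; both the chloro of compound 2 and the methoxy of compound 1 sit at or near no inhibition. Compound 4 is thus expected to fall back toward the level of compound 2, a step of a number 21.3 percentage points lower from compound 3 to compound 4 (beyond the scatter). The estimate for compound 4 in this assay is 8%, within 0% to 25%.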

Compound 4, a percentage reported as inhibition, at one concentration (the size of the read-out at that concentration, not a potency): 16.8%
For compound 4 the middle estimate is 8.8 percentage points below the measured one, within the range that was stated.
By their numbers in this assay, from the lowest: compound 2; then compound 4; then compound 3.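

In this assay, methyl at this place, on an aromatic carbon meta to a large group, does not sit at the chloro level: the change from chloro to methyl gives a number 15.9 percentage points higher from compound 2 to compound 4 (beyond the scatter) and the change from trifluoromethyl to methyl gives a number 12.5 percentage points lower from compound 3 to compound 4 (beyond the scatter) and so places methyl in the middle of the three numbers. Trifluoromethyl is therefore not the only group here that lifts the reading clearly above that of chloro, while steps to compound 1 cannot be read. Nothing measured on these compounds accounts for this order.

Going by these compounds, whether an amine, a carboxylic acid or a longer chain at this place would exceed the reading of compound 3 stays open. On these data alone, these are readings at one concentration, so how the groups rank in potency also stays open.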